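Swapping trifluoromethyl for methoxy on a pyrazolopyrimidine amine

A few compounds are considered here, and "the series" means these few. Any claim that something is new, unique, unknown or untested is made for them only; others in the source may bear on it.

Compound 1, with the structure `Nc1ncnc2c1cnn2-c1ccc(C(F)(F)F)cc1`, is the starting point of this piece. In a functional assay on NCI-H460 cells (Homo sapiens) for inhibition, with a stated time of 48 h (on this read-out higher numbers stand for weaker inhibition of growth and lower numbers for stronger inhibition of growth), compound 1 has the entry "not determined" (no result reported), so no number for it exists yet. A second compound, compound 2, with the structure `N#Cc1cnn(-c2ccc(C(F)(F)F)cc2)c1N`, shares the trifluoromethyl-bearing aromatic ring but carries a different core. In this assay compound 2 reaches only a limit of the method, > 150000 nM, and not a number. Within the data shown here, this is the single piece of evidence available, (the limit of > 150000 nM in this assay, at which 1 of the 2 values shown sits), and it concerns a core that compound 3 does not share.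

Compound 3, with the structure `COc1ccc(-n2ncc3c(N)ncnc32)cc1`, differs from compound 1 in one place: methoxy in place of trifluoromethyl on an aromatic carbon. Among the measured compounds shown here, no measured pair in this set shows such a swap, so the size and direction of the step in this assay cannot be read from the data; a change that stays within the usual scatter is as plausible as a clear shift either way. Compound 3 is therefore expected, with wide uncertainty, to give about 20000 nM in this assay, somewhere between 1500 nM and 150000 nM.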

Compound 3, concentration for 50% growth inhibition: > 150000 nM
Compound 3: no number, only a limit (the forecaster's own chance of this, stated with the estimate: 40%); at least 7.5-fold (0.87 log units) between middle value and limit.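

Among these compounds, no step from compound 1 to compound 3 can be read in this assay, as compound 1 has no number there. Compound 3 gives only a limit, > 150000 nM. The compounds shown leave open whether methoxy in place of trifluoromethyl changes growth inhibition at all, and in which direction.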